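The source may report more compounds than this note shows. Statements on the series, on what has been measured and on what is new or still open speak of the compounds shown alone.

In a functional assay on DU-145 cells (Homo sapiens) for cytotoxicity (on this read-out higher numbers stand for weaker inhibition of growth and lower numbers for stronger inhibition of growth), three compounds sharing one core have been measured. Compound 1 `COc1ccc(C2=C(c3ccc(SC)cc3)CC3CCCN3C2=O)cc1OC(=O)CNC(=O)OC(C)(C)C` gives 10000 nM. Compound 2 `COc1ccc(C2=C(c3ccc(SC)cc3)CC3CCCN3C2=O)cc1Br` gives 900 nM, and compound 3 `COc1ccc(C2=C(c3ccc(SC)cc3)CC3CCCN3C2=O)cc1C` gives 900 nM. Compound 3 therefore stands level with compound 2, and together they hold the lowest number of the three. Compound 4 `CSc1ccc(C2=C(c3ccc(C)c(C)c3)C(=O)N3CCCC3C2)cc1` has not yet been measured in this assay. It differs from compound 3 at one place: methyl in place of methoxy on an aromatic carbon.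

Among the measured compounds shown here, no measured step touches that methoxy group. All three concern the group that is methyl in compound 3. Two are large, an 11-fold lower number from compound 1 to compound 2 (1.05 log units; beyond the scatter) and an 11-fold lower number from compound 1 to compound 3 (1.05 log units; beyond the scatter), and both remove a far bigger group. The third, no change at the digits printed from compound 2 to compound 3 (within the scatter), is a swap of one small group for another and stays within the scatter. For the measured compounds named here, that closest precedent points to a small step, with a slight move toward a higher number as a cautious guess that the data cannot settle. The expected step is a 1.7-fold higher number from compound 3 to compound 4 (0.22 log units; within the scatter). Compound 4 is estimated at 1500 nM, within an expected range of 500 nM to 5000 nM.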

Compound 4, concentration for 50% growth inhibition: 500 nM
Compound 4: the middle estimate sits 3.0-fold (0.48 log units) above what was measured, within the range that was stated.
By their numbers in this assay, from the lowest: compounds 4, 2 and 3 (each within the scatter of the next); then compound 1.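

Among the compounds shown here, the earlier compounds varied only the other substituent on this ring, so this is the first step at the methoxy position, which lies ortho to a methyl group and para to a large group: in this assay, methyl in place of methoxy gives a 1.8-fold lower number from compound 3 to compound 4 (0.26 log units; within the scatter) and no step beyond the scatter. The change of 3-bromo-4-methoxyphenyl to 3,4-dimethylphenyl gives a 1.8-fold lower number from compound 2 to compound 4 (0.26 log units; within the scatter) and likewise stays inside that scatter, so at these two places on the ring the methoxy group and the bromine can both give way without a clear shift in growth inhibition. Nothing available explains why this position tolerates the swap.

The compounds shown leave open whether an amine, a carboxylic acid or a longer chain such as ethoxy at this position would shift the number beyond the scatter. They also leave open whether a plain hydrogen there would do so.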